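The source may report more compounds than this note shows. Statements on the series, on what has been measured and on what is new or still open speak of the compounds shown alone.

Of the compounds shown here, three sharing a core have been measured in a physicochemical assay for lipophilicity, using the shake flask method, in phosphate buffer, measured as octanol-water partition, with a stated time of 30 min, at pH 7.4; a lower number here means a more polar compound, a higher number a more lipophilic compound. Compound 1 `CN(c1ncco1)c1cnc(NCc2c(F)ccc3c2CCO3)n2cnnc12` gives 2.1, compound 2 `C[C@@H]1CC(=O)N(c2cnc(NCc3c(F)ccc4c3CCO4)n3cnnc23)C1` gives 1.8 and compound 3 `CN(C)Cc1ccc(C(=O)Nc2cnc(NCc3c(F)ccc4c3CCO4)n3cnnc23)cc1` gives 1.8. Compound 2 is therefore level with compound 3 at the digits shown, and close to compound 1.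

The next compound, compound 4 `CN(c1ccccc1)c1cnc(NCc2c(F)ccc3c2CCO3)n2cnnc12`, differs from compound 2 in one place: methyl(phenyl)amino in place of 4-methyl-2-oxopyrrolidin-1-yl on an aromatic carbon. In words, methyl(phenyl)amino replaces 4-methyl-2-oxopyrrolidin-1-yl on an aromatic carbon.

Going by the values given here, one measured step bears on this change: a number 0.30 log units lower from compound 1 to compound 2 (within the scatter). Its starting group, methyl(1,3-oxazol-2-yl)amino, is like the entering group an amino group carrying a methyl and an aromatic ring, so the same swap run in reverse points upward. Among the compounds with values here, no measured compound has a ring of carbon only at this place, so the size of the change remains uncertain.

An upward change larger than the scatter is expected, estimated as a number 1.00 log units higher from compound 2 to compound 4 (beyond the scatter). Compound 4 is estimated at 2.8, with an expected range from 2.2 to 3.4.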

Compound 4, distribution coefficient: 3.6
Compound 4: middle estimate off by 0.80 log units, on the low side; measured number above the stated range.
By their numbers in this assay, from the lowest: compounds 2, 3 and 1 (each within the scatter of the next); then compound 4.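

In this assay, going by these compounds alone, this position turns out to be far more sensitive than the earlier compounds suggested, since their only step here was small: a number 0.30 log units lower from compound 1 to compound 2 (within the scatter). Methyl(phenyl)amino in place of 4-methyl-2-oxopyrrolidin-1-yl gives a number 1.80 log units higher from compound 2 to compound 4 (beyond the scatter), a step well beyond anything seen before at this place. Keeping the methyl on the nitrogen and changing only the ring still matters, with phenyl in place of 1,3-oxazol-2-yl giving a number 1.50 log units higher from compound 1 to compound 4 (beyond the scatter), so two groups of similar outline need not behave alike here.

No measurement among those shown accounts for the size of these steps. Still open, as far as these compounds go, is whether an ethyl in place of that methyl, or a carboxylic acid on the phenyl, would move the number, and in which direction.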